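The compounds below may be only part of what the source reports. "The series", "measured", "known", "first", "only" and "open" are said of these compounds alone.

Working notes on the series. Compound 1 `O=C(N/N=C/c1cccnc1)c1ccc(-c2nc3ccccc3s2)cc1` carries a pyridin-3-yl on the carbon with a double bond to nitrogen. In an assay on isolated protein for inhibition of Maltase-glucoamylase (Homo sapiens), with a stated time of 15 min (a lower number here means a stronger inhibitor, a higher number a weaker inhibitor), compound 1 gives "not active" (no number reported), so no single number places it on the scale. Among the compounds with values here, compound 2 `COc1cc(/C=N/NC(=O)c2ccc(-c3nc4ccccc4s3)cc2)cc(OC)c1` is the only member with a numerical read-out: in this assay compound 2 gives 16200 nM, a weak result. Compound 3 `COc1cccc(/C=N/NC(=O)c2ccc(-c3nc4ccccc4s3)cc2)c1` has not yet been measured. It differs from compound 1 in one place: 3-methoxyphenyl in place of pyridin-3-yl on a carbon with a double bond to nitrogen. Within the data shown here, no measured step exists for this change, and compound 1 offers no number to step from, so any expectation rests on the weak value of compound 2 alone. The step from compound 1 to compound 3 in this assay is expected to be small, most likely staying at the weak end or returning no number at all. For compound 3 in this assay the expected value is 30000 nM, with a range from 10000 nM to 100000 nM.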

Compound 3, half-maximal inhibitory concentration: 11100 nM
Estimate against measurement, compound 3: 2.7-fold (0.43 log units) above; the range from low to high includes it.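

In this assay compound 3 gives 11100 nM, whereas compound 1 gives "not active" (no number reported). With 3-methoxyphenyl in place of pyridin-3-yl on the carbon with a double bond to nitrogen, the series therefore gains a second numerical read-out, though the size of this change cannot be read. Hydrogen in place of methoxy on an aromatic carbon gives a 1.5-fold lower number from compound 2 to compound 3 (0.16 log units; within the scatter), so the two methoxy-bearing compounds sit together at the weak end of the scale, and no measurement at hand accounts for either result.

Open, going by these compounds, is how an unsubstituted phenyl, or a phenyl carrying an amine or a carboxylic acid, would read at this carbon. Also open, on these data alone, is whether any group here can move the number beyond the scatter from that of compound 3.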